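The source may hold more compounds than are shown below. What is called first, only, known or untested is meant among the compounds shown, and "the series" means these compounds.

Values in a functional assay on A549 cells (Homo sapiens) for antiproliferative activity, read by sulforhodamine B assay, with a stated time of 3 days (on this read-out lower numbers stand for an effect already at smaller amounts and higher numbers for an effect only at larger amounts of compound), so far:
compound 1 `CCCC1=C(OCCC(C)C)C(CCC)(CCC)C(=O)/C(=C(O)\C=C\c2ccccc2)C1=O` gives 11.3 uM
compound 2 `CCCC1=C(OCC(C)C)C(CCC)(CCC)C(=O)/C(=C(O)\C=C\c2ccccc2)C1=O` gives 1.7 uM
compound 3 `COC1=C(CC=C(C)C)C(=O)/C(=C(O)/C=C/c2ccccc2)C(=O)C1(CC=C(C)C)CC=C(C)C` gives 10.3 uM

Compound 2 at 1.7 uM holds the lowest number of the three, and both other compounds sit beyond the scatter from it: compound 3 at 10.3 uM and compound 1 at 11.3 uM on the higher side.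

Next in the series is compound 4 `CCCOC1=C(CCC)C(=O)/C(=C(O)/C=C/c2ccccc2)C(=O)C1(CCC)CCC` with this difference from compound 2: hydrogen in place of methyl on a saturated chain carbon bound to two saturated chain carbons (hydrogen in place of methyl on a saturated chain carbon bound to two saturated chain carbons, which turns isobutoxy into propoxy).

For the measured compounds named here, one measured step bears on this change: a 6.6-fold lower number from compound 1 to compound 2 (0.82 log units; beyond the scatter) with isopropyl in place of isobutyl on a saturated chain carbon bound to an oxygen on an unsaturated carbon. That step also trims the oxygen-bound chain, so a change in this chain can move the number clearly. Going by the values given here, a single step does not fix the direction for a different trim, and no measured compound carries the propoxy group yet. With compound 2 at the low end of the three values, a higher number is the more likely outcome, though a step within the scatter remains possible. The expected step is a 2.4-fold higher number from compound 2 to compound 4 (0.37 log units; beyond the scatter) and is modest in size. The expected value for compound 4 is 4 uM (estimated range 1.2 uM to 13 uM).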

Compound 4, concentration for half-maximal effect: 1.9 uM
Compound 4: middle estimate off by 2.1-fold (0.32 log units), on the high side; low and high end bracket the measured number.
By their numbers in this assay, from the lowest: compounds 2 and 4 (each within the scatter of the next); then compounds 3 and 1 (each within the scatter of the next).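

In this assay, the methyl that separates isobutoxy from propoxy carries no visible weight: a 1.1-fold higher number from compound 2 to compound 4 (0.05 log units; within the scatter). A branch on that saturated chain carbon is therefore not needed for the low number, at least in this pair, and the clear change in the oxygen-bound chain lies in what separates these two chains from the chain of compound 1, as a 5.9-fold lower number from compound 1 to compound 4 (0.77 log units; beyond the scatter) shows alongside the earlier step, a 6.6-fold lower number from compound 1 to compound 2 (0.82 log units; beyond the scatter). Nothing measured explains why these chains group as they do.

The compounds shown leave open how far the oxygen-bound chain can vary around isobutoxy and propoxy while keeping the number low, for example with ethoxy, an unbranched butoxy, or a chain ending in an amine or a carboxylic acid. They also leave open whether the match between isobutoxy and propoxy holds when the three propyl groups of the shared core are replaced, for instance by the prenyl groups of compound 3, and whether it extends beyond this assay.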